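A few compounds are considered here, and "the series" means these few. Any claim that something is new, unique, unknown or untested is made for them only; others in the source may bear on it.

In a functional assay on OCI-Ly3 cells (Homo sapiens) for antiproliferative activity (a lower number here means that less compound is needed, a higher number that more compound is needed for the effect), compound 1 `CC(C)c1c(NC(=O)Nc2cnc(-n3nccn3)c(Cl)c2)cnc2ccccc12` gives 2420 nM and compound 2 `O=C(Nc1cnc(-n2nccn2)c(Cl)c1)Nc1cnc2ccccc2c1C1CC1` gives 1580 nM so the two cannot be told apart. Among the measured compounds shown here, the only measured step is a 1.5-fold lower number from compound 1 to compound 2 (0.19 log units; within the scatter) for cyclopropyl in place of isopropyl on an aromatic carbon. For the measured compounds named here, compound 3 `O=C(Nc1cnc(-n2nccn2)c(Cl)c1)Nc1cnc2ccc(Cl)cc2c1C1CC1` instead carries chloro in place of hydrogen on an aromatic carbon of compound 2, counted as chloro in place of hydrogen on an aromatic carbon and no measured step touches that place. The data therefore give no direction, and no step beyond the scatter is expected in this assay for now. The expected step is a 1.1-fold lower number from compound 2 to compound 3 (0.02 log units; within the scatter) in this estimate. For compound 3 the estimated value is 1500 nM with a range from 600 nM to 3500 nM as expected limits of the number.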

Compound 3, half-maximal effective concentration: 990 nM
Compound 3: the middle estimate sits 1.5-fold (0.18 log units) above what was measured; measured number inside the range.
By their numbers in this assay, from the lowest: compounds 3, 2 and 1 (each within the scatter of the next, the first and the last beyond it).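

Among the compounds shown here, the first change at this carbon of the core, a 1.6-fold lower number from compound 2 to compound 3 (0.20 log units; within the scatter), in this assay, stays within the scatter. A chloro group can therefore replace hydrogen at this place, on the ring of carbon only, without a change that these measurements can distinguish, so the place accepts one added chlorine atom. No measurement shown here offers an explanation for this result.

Going by these compounds, whether a methoxy group or an amine at this carbon would move the number beyond the scatter remains open. So does whether chloro would give the same result on the other carbons of that ring.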